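An Oxime Acetate With Its Double Bond Reversed

This account rests on a few compounds, and the source may have more. Where it says the series, first, only, none or still open, it means among the compounds named here.

Compound 1 `CCn1ccc2cc(/C(=N\O)c3cc(OC)c(OC)c(OC)c3)ccc21` and its acetylated partner, compound 2 `CCn1ccc2cc(/C(=N\OC(C)=O)c3cc(OC)c(OC)c(OC)c3)ccc21`, were both tested in a functional assay on A549 cells (Homo sapiens) for cytotoxicity, read by XTT assay, with a stated time of 72 h; a higher number here means a weaker inhibitor, a lower number a stronger inhibitor. Compound 1 gives > 10000 nM, which is a limit of the assay. Compound 2 gives > 10000 nM, also a limit. The measured step, a step that the two limits leave unreadable from compound 1 to compound 2, therefore has no readable size, and it offers no guide to a change in configuration. Compound 3 `CCn1ccc2cc(/C(=N/OC(C)=O)c3cc(OC)c(OC)c(OC)c3)ccc21` differs from compound 2 as follows: the two compounds have the same atoms and bonds and differ only in configuration as drawn: 1 of 1 stereo elements differ; a double bond is drawn E in compound 2 and Z in compound 3. Any readable number would mean stronger inhibition, so the expected step is an at least 2.5-fold lower number from compound 2 to compound 3 (0.39 log units; beyond the scatter), a tentative figure. For compound 3 the estimated value is 4000 nM, with an expected range of 300 nM to 10000 nM.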

Compound 3, half-maximal inhibitory concentration: > 10000 nM
Compound 3 ended at the assay's limit; the forecaster's own chance of this, stated with the estimate: 55%; middle value at least 2.5-fold (0.39 log units) away from the limit.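

Among these compounds, compound 2 and compound 3 both stop at a limit, so no step between them can be read: the limit of > 10000 nM in this assay, at which 3 of the 3 values shown sit. Going by these compounds, what the double bond's configuration or the acetyl group does to cytotoxicity stays open.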